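Weighing one change on compound 3 before its measurement

The source may hold more compounds than are shown below. What is called first, only, known or untested is meant among the compounds shown, and "the series" means these compounds.

Compound 1, `O=C(Nc1cccc(-n2cc(-c3ccncc3)c(-c3cc(O)cc(Cl)c3)n2)c1)Nc1ccc(Cl)c(Cl)c1`, gives in a functional assay on COLO 205 cells (Homo sapiens) for inhibition, read by sulforhodamine B assay, with a stated time of 48 h, tested at 0.01 uM (on this read-out lower numbers stand for a stronger effect and higher numbers for a weaker effect at the one concentration tested), the value 106%.
Compound 2, `COc1cc(Cl)cc(-c2nn(-c3cccc(NC(=O)Nc4cc(C(F)(F)F)cc(C(F)(F)F)c4)c3)cc2-c2ccncc2)c1`, gives in this assay the value 98%.
Compound 3, `COc1cc(Cl)cc(-c2nn(-c3cccc(NC(=O)Nc4ccc(Cl)c(Cl)c4)c3)cc2-c2ccncc2)c1`, gives in this assay the value 99%.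

Among these three numbers compound 3 stands second highest, and both its neighbours lie within the scatter of it: compound 2 is nearest, compound 1 furthest. Among the compounds with values here, the only one-place step among the measured compounds, a number 7 percentage points lower from compound 1 to compound 3 (within the scatter), stays within the scatter as well.

Compound 4, `COc1cc(Cl)cc(-c2nn(-c3cccc(NC(=O)c4cccc(C(F)(F)F)c4)c3)cc2-c2ccncc2)c1`, differs from compound 3 in one place: 3-(trifluoromethyl)phenyl in place of (3,4-dichlorophenyl)amino on a carbonyl carbon. Within the data shown here, no measured step touches this part of the molecule, so nothing in the data speaks for a change of read-out in this assay in either direction. All three measured values cluster together, and the step of a number 7 percentage points lower from compound 1 to compound 3 (within the scatter) shows no movement beyond the scatter. Compound 4 is therefore expected to give 100%, between 88% and 112%, so that the expected step of a number 1 percentage points higher from compound 3 to compound 4 (within the scatter) stays within the scatter.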

Compound 4, a percentage reported as activity, at one concentration (the size of the read-out at that concentration, not a potency): 108%
Compound 4: middle estimate off by 8 percentage points, on the low side; measured number inside the range.
By their numbers in this assay, from the lowest: compounds 2, 3, 1 and 4 (each within the scatter of the next).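

This is the first step shown at this place on the carbonyl carbon, and it is a large exchange: (3,4-dichlorophenyl)amino, with 1 hydrogen-bond donor, gives way to 3-(trifluoromethyl)phenyl, with 0 hydrogen-bond donors. Even so, this assay records a number 9 percentage points higher from compound 3 to compound 4 (within the scatter), so at this one concentration the read-out does not separate the two groups, and the change of the atom on the carbonyl carbon from nitrogen to ring carbon leaves no mark beyond the scatter. Nothing shown bears on why the number behaves this way.

Going by these compounds, what remains open is whether any group at this place, such as a benzylamino group or a piperidine, would move the number beyond the scatter. On these data alone, it is also open whether compound 3 and compound 4 would stay this close at a higher concentration.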